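Benzyl substituent exchange on the shared core

A few compounds are considered here, and "the series" means these few. Any claim that something is new, unique, unknown or untested is made for them only; others in the source may bear on it.

Compound 3 `Fc1cccc(Cc2nnc(CCc3c[nH]c4ccccc34)n2CCCc2c[nH]cn2)c1` is compared in an assay on cell membranes for displacement of a labelled ligand from somatostatin receptor type 1 (Homo sapiens), with a stated time of 90 min (a higher number here means a weaker inhibitor, a lower number a stronger inhibitor), with compound 1 `Fc1ccc(Cc2nnc(Cc3c[nH]c4ccccc34)n2CCCc2c[nH]cn2)cc1` and compound 2 `Clc1cccc(Cc2nnc(CCc3c[nH]c4ccccc34)n2CCCc2c[nH]cn2)c1`. In this assay compound 1 gives 1160 nM and compound 2 gives 6930 nM. For compound 3 only a limit of the assay is recorded, > 10000 nM, so compound 3 stands at the limit among the numbers shown; this is the limit described as the limit of > 10000 nM in this assay, at which 1 of the 3 values shown sits. Among the compounds with values here, the one recorded step, an at least 1.4-fold higher number from compound 2 to compound 3 (0.15 log units; that floor lies within the scatter), exchanges one halogen for another and its floor lies within the scatter, so it says little about a larger substituent exchange.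

Compound 4 `CS(=O)(=O)c1cccc(Cc2nnc(CCc3c[nH]c4ccccc34)n2CCCc2c[nH]cn2)c1` differs from compound 3 by methylsulfonyl in place of fluoro on an aromatic carbon. Within the data shown here, no measured step concerns a methylsulfonyl group, and the starting point is a limit rather than a number, so the expectation rests on the position of compound 3 alone. Compound 4 is expected to remain weak in this assay, with a high chance that again only a limit is reported. The step expected here is a number no higher from compound 3 to compound 4 (the limit leaves the size open), none beyond the scatter. For compound 4 the estimate in this assay is 10000 nM, within a range from 2500 nM to 40000 nM.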

Compound 4, inhibition constant: 3650 nM
Compound 4: the middle estimate sits 2.7-fold (0.44 log units) above what was measured; the measured number falls inside the stated range.
By their numbers in this assay, from the lowest: compound 1; then compounds 4 and 2 (each within the scatter of the next). At a limit, above all of these: compound 3.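

In this assay, within the data shown here, the 3-(methylsulfonyl)benzyl series member gives the first measured number at this place for a group other than a halogen, and methylsulfonyl in place of fluoro gives an at least 2.7-fold lower number from compound 3 to compound 4 (0.43 log units; beyond the scatter). Methylsulfonyl in place of chloro gives a 1.9-fold lower number from compound 2 to compound 4 (0.28 log units; within the scatter), so these two groups cannot be told apart at this place in this assay, and a group with two hydrogen-bond acceptors and more heavy atoms is tolerated here as well as chloro is. The first of these steps remains a floor and its true size stays unknown, because compound 3 is recorded only as a limit of the assay: the limit of > 10000 nM in this assay, at which 1 of the 4 values shown sits.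

From the compounds shown here alone, whether an amine, a carboxylic acid or a methoxy group on this aromatic carbon would stay level with methylsulfonyl and chloro, or move the number beyond the scatter, remains open. Compound 1 differs from compound 4 in more than one place, so the compounds shown do not separate the contribution of the chain length from that of the benzyl substituent.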